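This account rests on a few compounds, and the source may have more. Where it says the series, first, only, none or still open, it means among the compounds named here.

Two compounds have been measured so far in a functional assay on PC-12 cells (Rattus norvegicus) for cytotoxicity, read by MTT assay, with stated times of 2 h and 24 h, tested at 1 uM; a higher number here means a stronger effect of the compound at the concentration tested, a lower number a weaker effect:
Compound 1, `Oc1cc(C(F)(F)F)ccc1-c1nc(-c2ccccc2O)n(-c2ccccc2F)n1`, gives 63.4%.
Compound 2, `Oc1cc(C(F)(F)F)ccc1-c1nc(-c2ccccc2O)n(-c2ccccc2C(F)(F)F)n1`, gives 71%.

Compound 2 holds the top number shown, yet a number 7.6 percentage points higher from compound 1 to compound 2 (within the scatter) lies within the scatter, so compound 1 and compound 2 cannot be told apart. Compound 3, `COc1cccc(-n2nc(-c3ccc(C(F)(F)F)cc3O)nc2-c2ccccc2O)c1`, differs from compound 2 by 3-methoxyphenyl in place of 2-(trifluoromethyl)phenyl on an aromatic nitrogen. For the measured compounds named here, the one measured step also exchanged a group on an aromatic nitrogen and barely moved the read-out; the group entering in compound 3 is covered by no measured step. Compound 3 is therefore expected to show a step of a number 6 percentage points lower from compound 2 to compound 3 (within the scatter) in this assay, nothing beyond the scatter. Compound 3 is estimated at 65%, within 50% to 78%.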

Compound 3, a percentage reported as activity, at one concentration (the size of the read-out at that concentration, not a potency): 68.3%
Estimate against measurement, compound 3: 3.3 percentage points below; the measured number falls inside the stated range.
By their numbers in this assay, from the lowest: compounds 1, 3 and 2 (each within the scatter of the next).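

In this assay putting 3-methoxyphenyl on the aromatic nitrogen in place of 2-(trifluoromethyl)phenyl gives a number 2.7 percentage points lower from compound 2 to compound 3 (within the scatter) and in place of 2-fluorophenyl gives a number 4.9 percentage points higher from compound 1 to compound 3 (within the scatter). This position therefore now carries a ring with no fluorine, bearing a methoxy group instead, and the three compounds still cannot be told apart. No further data explain this result.

From the compounds shown here alone, whether any group here can move the read-out beyond the scatter stays open. A ring bearing an amine or a carboxylic acid, or a plain alkyl chain in place of the ring, would test that.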